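Compound 1 with 4-Fluorophenyl in Place of Isobutyl

The source may report more compounds than this note shows. Statements on the series, on what has been measured and on what is new or still open speak of the compounds shown alone.

Among the measured compounds shown here, in a functional assay on A549 cells (Homo sapiens) for inhibition, read by MTT assay, with a stated time of 72 h (a lower number here means a stronger inhibitor, a higher number a weaker inhibitor), compound 1 (`CC(C)CCN(CCCCCC(=O)NO)c1ncc(C(=O)NCCCn2ccnc2)s1`) gives 13000 nM as the higher of the two numbers so far, and compound 2 (`CC(C)CCN(CCCCCCC(=O)NO)c1ncc(C(=O)NCCCn2ccnc2)s1`) gives 5200 nM as the lower. Compound 3 (`O=C(CCCCCN(Cc1ccc(F)cc1)c1ncc(C(=O)NCCCn2ccnc2)s1)NO`) is not yet measured. It carries 4-fluorophenyl in place of isobutyl on a saturated chain carbon bound to a nitrogen on an aromatic ring. For the measured compounds named here, the only measured step (a 2.5-fold lower number from compound 1 to compound 2 (0.40 log units; beyond the scatter)) altered the hydroxycarbamoyl chain and not this place, so it is a loose guide. Going by the values given here, the expected change in this assay (a 1.9-fold lower number from compound 1 to compound 3 (0.27 log units; within the scatter)) is no larger than that step and points toward a lower number. For compound 3 the estimated value is 7000 nM (likely range 2500 nM to 20000 nM).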

Compound 3, half-maximal inhibitory concentration: 54000 nM
Compound 3: middle estimate off by 7.7-fold (0.89 log units), on the low side; the whole stated range lies below it.
By their numbers in this assay, from the lowest: compound 2; then compound 1; then compound 3.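

In this assay, 4-fluorophenyl in place of isobutyl gives a 4.2-fold higher number from compound 1 to compound 3 (0.62 log units; beyond the scatter) and so moves toward a weaker inhibitor. This shows that the place on a saturated chain carbon bound to a nitrogen on an aromatic ring affects the result, as the hydroxycarbamoyl chain did earlier. No measurement here explains the change. The compounds shown leave open whether the aromatic ring or the fluorine goes with the change. Plain phenyl or cyclohexyl at this place would separate the two.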